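From Bromo to Chloro: One Atom Changes on a Shared Core

A few compounds are considered here, and "the series" means these few. Any claim that something is new, unique, unknown or untested is made for them only; others in the source may bear on it.

Compound 1, `CN(C)/N=N\c1ccnc2c(Br)cccc12`, was tested in a toxicity assay on the whole organism (P388 cells) for cytotoxicity, with Mus musculus as the target, with a stated time of 9 days, at a dose of 30 mg/kg by the intraperitoneal route (on this read-out higher numbers stand for a weaker effect at the one dose given and lower numbers for a stronger effect), and in that test compound 1 gives 4.8%. A second compound, compound 2, `CN(C)/N=N\c1ccnc2ccc(Br)cc12`, carries its bromo group at a different spot on the same core; in this assay compound 2 gives 10%. These two numbers lie within the scatter of each other, so they cannot be ranked; compound 1 merely has the lower of the two numbers recorded so far.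

Compound 3, `CN(C)/N=N\c1ccnc2c(Cl)cccc12`, has not yet been measured. It differs from compound 1 by chloro in place of bromo on an aromatic carbon: one bromine atom leaves and one chlorine atom enters at the same aromatic carbon of the shared core. Among the measured compounds shown here, no measured pair shows what such a swap does here. Given that compound 1 gives 4.8%, the step from compound 1 to compound 3 is expected to be small, a number 2.2 percentage points higher from compound 1 to compound 3 (within the scatter), not beyond the scatter in either direction. Compound 3 is therefore estimated at 7%, with a range from 0% to 20%.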

Compound 3, a percentage reported as activity, at one dose (the size of the read-out at that dose, not a potency): -15%
For compound 3 the middle estimate is 22 percentage points above the measured one, and the stated range ends above it.
By their numbers in this assay, from the lowest: compound 3; then compounds 1 and 2 (each within the scatter of the next).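

Putting chloro in place of bromo on this aromatic carbon is not a neutral swap: in this assay the change gives a number 19.8 percentage points lower from compound 1 to compound 3 (beyond the scatter) and leaves compound 3 at -15%, and lower numbers here stand for a stronger effect at the one dose given. Compounds 1 and 2, whose numbers lie within the scatter of each other, could not show that this position responds at all, whereas exchanging one halogen atom for another on the same carbon moves the read-out by more than the scatter. No measurement among the data shown accounts for this step.

As far as these compounds go, whether chloro in place of bromo would act the same way at the spot that carries bromo in compound 2 stays open. So does the outcome with a fluoro group, a methoxy group or an amine on this aromatic carbon of the shared core.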